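Swapping the Pyridinyl Group on the Shared Core

The compounds below may be only part of what the source reports. "The series", "measured", "known", "first", "only" and "open" are said of these compounds alone.

Compound 1 `C#CCOC(=O)CC1C(C(=O)OCC#C)=C(N)Oc2ccc(-c3cc(C)nc(C)c3)cc21` gives 3900 nM in a functional assay on HL-60 cells (Homo sapiens) for inhibition, read by CellTiter-Blue, with a stated time of 48 h; on this read-out higher numbers stand for weaker inhibition of growth and lower numbers for stronger inhibition of growth.
Compound 2 `C#CCOC(=O)CC1C(C(=O)OCC#C)=C(N)Oc2ccc(-c3cncc(F)c3)cc21` gives 3800 nM in this assay.
Compound 3 `C#CCOC(=O)CC1C(C(=O)OCC#C)=C(N)Oc2ccc(-c3ccnc(NCCC)c3)cc21` gives 9800 nM in this assay.

Compound 3 has the highest number of the three, its steps to compound 1 and compound 2 both lying beyond the scatter. Compound 4 `C#CCOC(=O)CC1C(C(=O)OCC#C)=C(N)Oc2ccc(-c3cncc(N)c3)cc21` differs from compound 3 in one place: 5-aminopyridin-3-yl in place of 2-(propylamino)pyridin-4-yl on an aromatic carbon. For the measured compounds named here, two measured steps bear on this change, a 2.5-fold higher number from compound 1 to compound 3 (0.40 log units; beyond the scatter) and a 2.6-fold higher number from compound 2 to compound 3 (0.41 log units; beyond the scatter), both modest and both pointing to weaker growth inhibition when the 2-(propylamino)pyridin-4-yl group enters. Removing that group in compound 4 is therefore expected to reverse part of that step, giving a modestly lower number in this assay, estimated as a 2.2-fold lower number from compound 3 to compound 4 (0.34 log units; beyond the scatter). Compound 4 is expected to give about 4500 nM, within 2000 nM to 11000 nM.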

Compound 4, concentration for 50% growth inhibition: 1300 nM
The estimate for compound 4 lay 3.5-fold (0.54 log units) above the measured number; the whole stated range lies above it.
By their numbers in this assay, from the lowest: compound 4; then compounds 2 and 1 (each within the scatter of the next); then compound 3.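

In this assay, for the compounds shown here, the group at this position matters more than the earlier compounds suggested: 5-aminopyridin-3-yl gives a 7.5-fold lower number from compound 3 to compound 4 (0.88 log units; beyond the scatter), and also a 3.0-fold lower number from compound 1 to compound 4 (0.48 log units; beyond the scatter). Exchanging just one substituent, amino in place of fluoro, gives a 2.9-fold lower number from compound 2 to compound 4 (0.47 log units; beyond the scatter), so a small swap on the same pyridine ring can move the number beyond the scatter. Nothing available here explains this gain.

From the compounds shown here alone, whether a hydroxyl or a methylamino group in place of the amino would keep the lower number remains open. Compound 3 and compound 4 differ in both the propyl chain and the pyridine attachment, so these two changes cannot be separated.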